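Chlorine shift on the N-aryl group, compound 2 to 3

The source may hold more compounds than are shown below. What is called first, only, known or untested is meant among the compounds shown, and "the series" means these compounds.

Values in a functional assay on MCF7 cells (Homo sapiens) for cytotoxicity, read by sulforhodamine B assay, with a stated time of 48 h; on this read-out lower numbers stand for stronger inhibition and higher numbers for weaker inhibition:
- compound 1 `Nc1c(-c2nc3ccccc3[nH]2)cc(-c2ccccc2)n1-c1ccccn1`: 934 nM
- compound 2 `Nc1c(-c2nc3ccccc3[nH]2)cc(-c2ccccc2)n1-c1cccc(Cl)c1`: 1700 nM

Compound 2, at 1700 nM, cannot be told apart from compound 1 at 934 nM. The next compound, compound 3 `Nc1c(-c2nc3ccccc3[nH]2)cc(-c2ccccc2)n1-c1ccc(Cl)cc1`, carries 4-chlorophenyl in place of 3-chlorophenyl on an aromatic nitrogen. For the measured compounds named here, only one measured step bears on this, a 1.8-fold higher number from compound 1 to compound 2 (0.26 log units; within the scatter). It exchanges a different group on the same aromatic nitrogen and lies within the scatter. Going by the values given here, no measurement yet compares two chlorophenyl isomers, so the evidence is indirect. In this assay no step beyond the scatter is expected. The expected step is a 1.1-fold lower number from compound 2 to compound 3 (0.05 log units; within the scatter). For compound 3 the estimated value is 1500 nM, with an expected range of 600 nM to 3800 nM.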

Compound 3, half-maximal inhibitory concentration: 934 nM
Estimate against measurement, compound 3: 1.6-fold (0.21 log units) above; the range from low to high includes it.
By their numbers in this assay, from the lowest: compounds 1, 3 and 2 (each within the scatter of the next).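

In this assay, for the compounds shown here, moving the chlorine on the aromatic nitrogen from 3-chlorophenyl to 4-chlorophenyl gives a 1.8-fold lower number from compound 2 to compound 3 (0.26 log units; within the scatter) and so provides the first direct comparison of two chlorophenyl isomers at this position. Replacing pyridin-2-yl with 4-chlorophenyl at the same nitrogen gives no change at the digits printed from compound 1 to compound 3 (within the scatter) and so adds a second exchange of the aryl group that stays within the scatter; across compounds 1, 2 and 3, none of the three groups separates from the others. No supporting measurement explains these values.

Going by these compounds, it remains open whether a 2-chlorophenyl group, a small alkyl group such as methyl, or a chain ending in an amine on this nitrogen would give a step beyond the scatter. The phenyl, amino and 1H-benzimidazol-2-yl groups are the same in all compounds shown, so changes at those places remain untested here.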